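The source may hold more compounds than are shown below. What is called first, only, known or untested is meant among the compounds shown, and "the series" means these compounds.

Compound 1 `O=C(/C(=N/O)Nc1ccc(F)c(Br)c1)C1CCN(S(=O)(=O)NCc2ccccc2)CC1` carries a sulfonamide whose nitrogen bears a benzyl group. Tested in an assay for inhibition of Tryptophan 2,3-dioxygenase (Homo sapiens), with a stated time of 1 h (on this read-out lower numbers stand for stronger inhibition and higher numbers for weaker inhibition), compound 1 gives > 100000 nM, which is a limit of the assay rather than a number. Compound 2 `O=C(Nc1ccccc1)[C@H]1CC[C@H](C(=O)/C(=N/O)Nc2ccc(F)c(Br)c2)CC1` shares the same core but joins it to a different ring. In this assay compound 2 also gives > 100000 nM, again a limit and not a measured number. Going by the values given here, compound 1 thus stands at the limit, and with nothing measured beyond it, no step between measured compounds can be drawn; the only evidence is the limit of > 100000 nM in this assay, at which 2 of the 2 values shown sit.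

The next compound is compound 3 `O=C(/C(=N/O)Nc1ccc(F)c(Br)c1)C1CCN(S(=O)(=O)Nc2ccccc2)CC1`, which differs from compound 1 by phenyl in place of benzyl on a sulfonamide nitrogen. Among the compounds with values here, since both known values sit at the limit, there is no measured step to build on. The expected step is a step that the limit leaves unreadable from compound 1 to compound 3, that is, none beyond the usual scatter. Compound 3 is therefore estimated at 150000 nM, with a likely range from 50000 nM to 500000 nM, and a further limit reading would be no surprise.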

Compound 3, half-maximal inhibitory concentration: 65700 nM
Compound 3: middle estimate off by 2.3-fold (0.36 log units), on the high side, and the stated range covers the measured number.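

In this assay compound 3 gives 65700 nM, the only true number among the compounds shown, so a change on this sulfonamide nitrogen can give a measured number. Phenyl in place of benzyl on a sulfonamide nitrogen gives an at least 1.5-fold lower number from compound 1 to compound 3 (0.18 log units; that floor lies within the scatter); this is only a floor, and the true size of the step cannot be read, so the change may matter little or a great deal. Compound 1 remains a limit and not a number, which is what keeps the step open-ended: the limit of > 100000 nM in this assay, at which 2 of the 3 values shown sit.

The compounds shown leave open what a methyl group or a phenethyl group on this nitrogen would read, and whether a phenyl ring carrying a methoxy group or a carboxylic acid would shift the number from that of compound 3. They also leave open whether the same change, benzylamino to anilino, would give a readable step on a different part of the molecule or with another group in place of the shared core.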